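This account rests on a few compounds, and the source may have more. Where it says the series, first, only, none or still open, it means among the compounds named here.

In an ADME assay on HEp-2 cells (Homo sapiens) for cytotoxicity, with a stated time of 4 days (a lower number here means that less compound is tolerated, a higher number that more compound is tolerated), compound 3, `CS(=O)(=O)c1nn(Cc2nc3cc(Cl)ccc3n2CCCO)c2cnccc12`, gives > 100000 nM, which is a limit of the assay rather than a measured number. Compound 1, `CS(=O)(=O)CCCn1c(Cn2cc(S(C)(=O)=O)c3ccccc32)nc2cc(Cl)ccc21`, gives > 100000 nM in this assay, again a limit. Compound 2, `CN(C)S(=O)(=O)c1cn(Cc2nc3cc(Cl)ccc3n2CCCS(C)(=O)=O)c2ccccc12`, likewise gives > 100000 nM in this assay, also a limit. Within the data shown here, the one single change among the measured compounds, a step that the two limits leave unreadable from compound 1 to compound 2, is therefore unreadable, since (the limit of > 100000 nM in this assay, at which 3 of the 3 values shown sit). Compound 4, `CS(=O)(=O)c1nn(Cc2nc3cc(Cl)ccc3n2CCC(O)C(F)F)c2cnccc12`, differs from compound 3 by difluoromethyl in place of hydrogen on a saturated chain carbon bound to an oxygen on a saturated carbon and a saturated chain carbon. Among the measured compounds shown here, no measured step bears on this change, and every value shown sits at the limit, so no shift beyond the scatter is expected. The expected step is a step that the limit leaves unreadable from compound 3 to compound 4. Compound 4 is therefore estimated to give about 150000 nM in this assay, within 50000 nM to 500000 nM, most likely again reported only as a limit.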

Compound 4, half-maximal cytotoxic concentration: > 100000 nM
Compound 4: only a limit was reported (the forecaster's own chance of this, stated with the estimate: 80%); the middle value does not contradict the limit.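

No size can be read for the change from compound 3 to compound 4, since both results are limits rather than measured numbers: the limit of > 100000 nM in this assay, at which 4 of the 4 values shown sit.

The compounds shown leave open at what concentration any of them would become cytotoxic in this assay, and whether difluoromethyl in place of hydrogen alters that concentration.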